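The compounds below may be only part of what the source reports. "The series", "measured", "known", "first", "only" and "open" are said of these compounds alone.

Measured so far in a functional assay on CHO cells for antagonist activity at growth hormone secretagogue receptor type 1 (Homo sapiens); a lower number here means a stronger inhibitor, a higher number a weaker inhibitor:
- compound 1 `CCc1ccc(Cn2c(CCc3ccccc3)nnc2[C@H](NC(=O)c2ccccn2)c2c[nH]c3ccccc23)cc1` gives 513 nM
- compound 2 `COc1ccc(Cn2c(CCc3ccccc3)nnc2[C@H](NC(=O)c2ccccn2)c2c[nH]c3ccccc23)cc1` gives 12 nM
- compound 3 `COc1ccc(Cn2c(CCc3ccccc3)nnc2[C@H](NC(=O)c2cnccn2)c2c[nH]c3ccccc23)cc1` gives 530 nM

Compound 2 is the reference point of the set. Changing its amide aryl group, (pyrazin-2-yl in place of pyridin-2-yl on a carbonyl carbon), produces a large loss, a 44-fold higher number from compound 2 to compound 3 (1.65 log units; beyond the scatter). Changing instead the substituent on the benzyl ring, (ethyl in place of methoxy on an aromatic carbon), produces a loss of about the same size, a 43-fold higher number from compound 2 to compound 1 (1.63 log units; beyond the scatter). In this assay compound 1 and compound 3 therefore stand at much the same level.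

Compound 4 `CCc1ccc(Cn2c(CCc3ccccc3)nnc2[C@H](NC(=O)c2cnccn2)c2c[nH]c3ccccc23)cc1` is not yet measured. For the measured compounds named here, it differs from compound 3 by ethyl in place of methoxy on an aromatic carbon, the same change as the one already seen from compound 2 to compound 1; the place lines of the two changes read alike word for word, and the two cores differ only by pyrazin-2-yl in place of pyridin-2-yl on a carbonyl carbon. Whether the loss seen in a 43-fold higher number from compound 2 to compound 1 (1.63 log units; beyond the scatter) repeats on the pyrazinyl core is not known from these three compounds alone. A step of comparable direction is expected, a 15-fold higher number from compound 3 to compound 4 (1.18 log units; beyond the scatter), but a weaker result than simple addition of the two losses would not be surprising, since the number for compound 3 is already high. Compound 4 is estimated at 8000 nM, likely between 1500 nM and 40000 nM.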

Compound 4, antagonist equilibrium constant: 76 nM
Compound 4: middle estimate off by 110-fold (2.02 log units), on the high side; measured number outside the range, below it.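

In this assay, ethyl in place of methoxy does not carry from one core to the other: on the pyrazin-2-yl amide the step is a 7.0-fold lower number from compound 3 to compound 4 (0.84 log units; beyond the scatter), opposite in direction to the loss on the pyridin-2-yl amide: the same change on two cores in this assay, a 43-fold higher number (1.63 log units; beyond the scatter) from compound 2 to compound 1 and a 7.0-fold lower number (0.84 log units; beyond the scatter) from compound 3 to compound 4, 300-fold (2.47 log units) apart, beyond the scatter of two such steps Read the other way, pyrazin-2-yl in place of pyridin-2-yl also depends on its partner group, since on the 4-ethylbenzyl core the step is a 6.8-fold lower number from compound 1 to compound 4 (0.83 log units; beyond the scatter), against a loss on the 4-methoxybenzyl core: the same change on two cores in this assay, a 44-fold higher number (1.65 log units; beyond the scatter) from compound 2 to compound 3 and a 6.8-fold lower number (0.83 log units; beyond the scatter) from compound 1 to compound 4, 300-fold (2.47 log units) apart, beyond the scatter of two such steps The two changes are therefore not additive across these four compounds, but a single pair of cores gives no rule for other cores and does not show what lies behind the reversal.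

Going by these compounds, whether the reversal extends to other groups at the same place on the benzyl ring, such as chloro or a longer chain like propyl, remains open. Also open, on these data alone, is whether it survives when an amine replaces the amide aryl group.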